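Amide nitrogen substitution on a triazole carboxamide: predicting compound 4

The source may hold more compounds than are shown below. What is called first, only, known or untested is meant among the compounds shown, and "the series" means these compounds.

Measured so far:
compound 1 `COc1ccc(-n2nc(C(N)=O)nc2-c2cc(OC)c(OC)c(OC)c2)cc1`: 71%
compound 2 `CCNC(=O)c1nc(-c2cc(OC)c(OC)c(OC)c2)n(-c2ccc(OC)cc2)n1`: 58%
compound 3 `COc1ccc(-n2nc(C(=O)Nc3ccc(C(F)(F)F)cc3)nc2-c2cc(OC)c(OC)c(OC)c2)cc1`: 56%

In a functional assay on the whole organism for inhibition, with Rattus norvegicus as the target, read by paw edema, with stated times of 30 min and 4 h, at a dose of 0.28 mmol/kg by the oral route (on this read-out lower numbers stand for less inhibition and higher numbers for more inhibition at the one dose given (going by the name of the read-out)), compound 1 stands highest of the three numbers; its nearest neighbour is compound 2, and compound 3 lies furthest below it. Compound 4 `COc1ccc(-n2nc(C(=O)Nc3ccc(O)cc3)nc2-c2cc(OC)c(OC)c(OC)c2)cc1` carries the change (4-hydroxyphenyl in place of hydrogen on an amide-type nitrogen). Going by the values given here, two measured steps bear on this: a number 13 percentage points lower from compound 1 to compound 2 (beyond the scatter) and a number 15 percentage points lower from compound 1 to compound 3 (beyond the scatter), both modest losses on adding a substituent to the amide nitrogen. The further step a number 2 percentage points lower from compound 2 to compound 3 (within the scatter) shows that the two substituents themselves hardly differ. A modest loss is therefore expected for compound 4, of about a number 15 percentage points lower from compound 1 to compound 4 (beyond the scatter). Compound 4 is estimated at 56%, in the range 42% to 70%.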

Compound 4, a percentage reported as inhibition, in the whole organism at one dose (the size of the read-out at that dose, not a potency): 37%
Compound 4: middle estimate off by 19 percentage points, on the high side; the measured number lies below the stated range.
By their numbers in this assay, from the lowest: compound 4; then compounds 3 and 2 (each within the scatter of the next); then compound 1.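

The amide nitrogen is less indifferent to its substituent than compounds 2 and 3 suggested, with a number 34 percentage points lower from compound 1 to compound 4 (beyond the scatter) as the largest loss seen at this position. The group on the phenyl ring matters as well: hydroxy in place of trifluoromethyl gives a number 19 percentage points lower from compound 3 to compound 4 (beyond the scatter), and 4-hydroxyphenyl in place of ethyl gives a number 21 percentage points lower from compound 2 to compound 4 (beyond the scatter). Nothing available explains this drop.

On these data alone, whether an amine or a carboxylic acid on that phenyl ring would track with hydroxy or with trifluoromethyl remains open. So does the effect of a longer chain on the amide nitrogen.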